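The source may hold more compounds than are shown below. What is called first, only, known or untested is meant among the compounds shown, and "the series" means these compounds.

Among the measured compounds shown here, compound 2 `COc1ccc(-c2cn(CC(=O)Nc3nc4ccccc4s3)nn2)cc1` is one of two compounds measured in a functional assay on BMDM cells (Mus musculus, strain C57BL/6) for inhibition, with a stated time of 2 days (on this read-out higher numbers stand for weaker inhibition and lower numbers for stronger inhibition), where compound 2 gives 1330 nM. Its only companion, compound 1 `Nc1cccc(-c2cn(CC(=O)Nc3nc4ccccc4s3)nn2)c1`, gives 1110 nM in this assay, and the step of a 1.2-fold higher number from compound 1 to compound 2 (0.08 log units; within the scatter) leaves the pair within the scatter, so the two numbers cannot be told apart. Compound 3 `N#Cc1ccc(-c2cn(CC(=O)Nc3nc4ccccc4s3)nn2)cc1` differs from compound 2 by cyano in place of methoxy on an aromatic carbon. For the measured compounds named here, no measured step touches this change; the single known step, a 1.2-fold higher number from compound 1 to compound 2 (0.08 log units; within the scatter), concerns a different group and stayed within the scatter. Compound 3 is therefore expected to show no step beyond the scatter, a 1.0-fold lower number from compound 2 to compound 3 (0.01 log units; within the scatter). The estimate for compound 3 is 1300 nM, between 500 nM and 3500 nM.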

Compound 3, half-maximal inhibitory concentration: > 30000 nM
Compound 3 ended at the assay's limit; the forecaster's own chance of this, stated with the estimate: 5%; middle value at least 23-fold (1.36 log units) from the limit.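

Among the compounds shown here, the position para to a large group on the six-membered aromatic ring proves sensitive to what sits there: cyano in place of methoxy gives an at least 22-fold higher number from compound 2 to compound 3 (1.35 log units; beyond the scatter), the first step beyond the scatter. The 4-cyanophenyl in place of 3-aminophenyl likewise gives an at least 27-fold higher number from compound 1 to compound 3 (1.43 log units; beyond the scatter), so both earlier groups stand well apart from it. Compound 3 sits at a limit, not at a number: the limit of > 30000 nM in this assay, at which 1 of the 3 values shown sits.

From the compounds shown here alone, the true size of both steps therefore stays open. So does whether the loss is peculiar to cyano, since a carboxylic acid or a trifluoromethyl group in the same place would be needed to tell.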